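A few compounds are considered here, and "the series" means these few. Any claim that something is new, unique, unknown or untested is made for them only; others in the source may bear on it.

Compound 2 `CCN(CC)S(=O)(=O)c1ccc(S(=O)(=O)N2CCC[C@@H](C(=O)NC3CCOCC3)C2)cc1` and compound 1 `CCN(CC)S(=O)(=O)c1ccc(S(=O)(=O)N2CCC[C@@H](C(=O)NC3COC3)C2)cc1` share the same core and differ only in the ring attached to the amide nitrogen. Among the measured compounds shown here, in a functional assay on MIA PaCa-2 cells (Homo sapiens) for inhibition, read by MTT assay, with a stated time of 7 days (on this read-out higher numbers stand for weaker inhibition and lower numbers for stronger inhibition), compound 1 gives 2340 nM, and in this assay compound 2 gives 3770 nM, which is the higher of the two numbers measured so far. The step of a 1.6-fold higher number from compound 1 to compound 2 (0.21 log units; within the scatter) shows that swapping one of these two oxygen-containing rings for the other barely moved the read-out. Compound 3 `CCN(CC)S(=O)(=O)c1ccc(S(=O)(=O)N2CCC[C@@H](C(=O)N[C@H]3CCOC3)C2)cc1` takes the next step in the same direction: oxolan-3-yl in place of oxan-4-yl on an amide-type nitrogen. For the measured compounds named here, the only step that bears on this change is a 1.6-fold higher number from compound 1 to compound 2 (0.21 log units; within the scatter), and it stayed inside the usual scatter, so no step beyond the scatter is expected in this assay here either. Compound 3 is therefore estimated at 3000 nM, within a range of 1500 nM to 6000 nM, which would mean an expected step of a 1.3-fold lower number from compound 2 to compound 3 (0.10 log units; within the scatter).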

Compound 3, half-maximal inhibitory concentration: 1670 nM
Compound 3: middle estimate off by 1.8-fold (0.25 log units), on the high side, within the range that was stated.
By their numbers in this assay, from the lowest: compounds 3, 1 and 2 (each within the scatter of the next, the first and the last beyond it).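

In this assay this change gives the first step among these rings on the amide-type nitrogen to pass the usual scatter: oxolan-3-yl in place of oxan-4-yl gives a 2.3-fold lower number from compound 2 to compound 3 (0.35 log units; beyond the scatter) and counts as a modest step. Set against oxetan-3-yl, the same group gives a 1.4-fold lower number from compound 1 to compound 3 (0.15 log units; within the scatter) and stays within the scatter, so only compound 2 and compound 3 can be told apart, and ring size shows no steady trend across the three compounds. Nothing available explains the difference between these rings.

Going by these compounds, whether a cyclopentyl ring, with carbon where the ring oxygen stands, would read the same remains open. So do a piperidin-4-yl ring, which carries an amine, and the mirror-image form of the stereocentre in oxolan-3-yl.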